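A Phenethyl Triazole Takes the Place of Tert-Butyl

A few compounds are considered here, and "the series" means these few. Any claim that something is new, unique, unknown or untested is made for them only; others in the source may bear on it.

Compound 2 `CC(C)(C)c1cn(Cc2cc(=O)oc3cc(O)ccc23)nn1` is tested in a functional assay on SW-620 cells (Homo sapiens) for inhibition, read by MTT assay, with a stated time of 72 h; on this read-out lower numbers stand for stronger inhibition and higher numbers for weaker inhibition. Compound 2 gives only a limit there, > 100000 nM. Compound 1 `O=c1cc(Cn2cc(CCO)nn2)c2ccc(O)cc2o1` likewise gives only a limit, > 100000 nM. Among the compounds with values here, the one measured step, a step that the two limits leave unreadable from compound 1 to compound 2, is unreadable for that reason, as the limit of > 100000 nM in this assay, at which 2 of the 2 values shown sit, shows. Compound 3 `O=c1cc(Cn2cc(CCc3ccccc3)nn2)c2ccc(O)cc2o1` differs from compound 2 by phenethyl in place of tert-butyl on an aromatic carbon. Within the data shown here, no measured step bears on this change, so no direction beyond the scatter can be read from the data. Compound 3 is therefore expected to remain near the same limit, estimated at 100000 nM with a range of 20000 nM to 300000 nM. The expected step of a number no higher from compound 2 to compound 3 (the limit leaves the size open) is essentially none.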

Compound 3, half-maximal inhibitory concentration: 84400 nM
Estimate against measurement, compound 3: 1.2-fold (0.07 log units) above; measured number inside the range.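

Within the data shown here, with phenethyl on this aromatic carbon, compound 3 is the only one of the three compounds to give a number rather than a limit in this assay. The change gives an at least 1.1-fold lower number from compound 2 to compound 3 (0.07 log units; that floor lies within the scatter), and the swap on the chain gives an at least 1.1-fold lower number from compound 1 to compound 3 (0.07 log units; that floor lies within the scatter). How large either step truly is stays unreadable, because compound 1 and compound 2 give only limits: the limit of > 100000 nM in this assay, at which 2 of the 3 values shown sit.

The compounds shown leave open whether a longer chain ending in phenyl, or an amine on the phenyl ring, would carry the number clearly beyond the scatter.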